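Piperidine substituent change in the triazolyl-indole series

This account rests on a few compounds, and the source may have more. Where it says the series, first, only, none or still open, it means among the compounds named here.

Compound 2 `O[C@@H]1Cc2ccccc2[C@H]1NC1CCN(CCCc2c[nH]c3ccc(-n4cnnc4)cc23)CC1` gives 6.6 nM in an assay on CHO cells for displacement of a labelled ligand from 5-hydroxytryptamine receptor 1D (Homo sapiens) (a lower number here means a stronger inhibitor, a higher number a weaker inhibitor), the highest of the two numbers measured; the nearest is compound 1 `C[C@@H](NCC1CCN(CCCc2c[nH]c3ccc(-n4cnnc4)cc23)CC1)c1ccccc1`, with 1.4 nM. Among the compounds with values here, the only measured step, a 4.7-fold higher number from compound 1 to compound 2 (0.67 log units; beyond the scatter), swapped the group on the saturated ring carbon and is the sole guide. Within the data shown here, compound 3 `CN(C1CCN(CCCc2c[nH]c3ccc(-n4cnnc4)cc23)CC1)S(=O)(=O)c1ccccc1` carries methyl(phenylsulfonyl)amino in place of (2-hydroxy-2,3-dihydro-1H-inden-1-yl)amino on a saturated ring carbon; the leaving and entering groups differ in hydrogen-bond donors, and no measured step covers such a change directly. On that basis, a 3.0-fold higher number from compound 2 to compound 3 (0.48 log units; beyond the scatter) is expected, a modest step toward a higher number. Compound 3 is estimated at 20 nM, within 4 nM to 100 nM.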

Compound 3, half-maximal inhibitory concentration: 1.5 nM
Estimate against measurement, compound 3: 13-fold (1.12 log units) above; measured number below the stated range.
By their numbers in this assay, from the lowest: compounds 1 and 3 (each within the scatter of the next); then compound 2.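

Replacing (2-hydroxy-2,3-dihydro-1H-inden-1-yl)amino on the saturated ring carbon with methyl(phenylsulfonyl)amino, which has 0 hydrogen-bond donors, gives a 4.4-fold lower number from compound 2 to compound 3 (0.64 log units; beyond the scatter) in this assay, so in this pair the loss of donors does not raise the number. Against ((1-phenylethyl)amino)methyl the same group gives a 1.1-fold higher number from compound 1 to compound 3 (0.03 log units; within the scatter), so two differently built groups at this position read alike. No evidence on hand accounts for either step.

The compounds shown leave open whether the phenyl, the sulfonyl or the methyl on the nitrogen matters most. A methylsulfonyl or benzoyl group would help separate these parts.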